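The compounds below may be only part of what the source reports. "The series", "measured", "known", "first", "only" and "open" are said of these compounds alone.

In a functional assay on MCF7 cells (Homo sapiens) for antiproliferative activity, read by MTT assay (a lower number here means a stronger inhibitor, a higher number a weaker inhibitor), compound 1 `CCCCC/C=C\C/C=C\CCCCCCCC1(O)CC(=O)c2c(O)cc(O)cc2O1` gives 17500 nM. Compound 2 `CCCC/C=C\CCCCCCCCCc1cc(=O)c2c(O)cc(OCOC)c(C)c2o1` gives only a limit of the assay, > 67200 nM. Compound 3 `CCCC/C=C\CCCCCCCCCc1cc(=O)c2c(O)cc(OCOC)cc2o1` likewise gives only a limit, > 67200 nM. Within the data shown here, the one step between measured compounds, a hydrogen in place of a methyl on an aromatic carbon, is a step that the two limits leave unreadable from compound 2 to compound 3, unreadable because the limit of > 67200 nM in this assay, at which 2 of the 3 values shown sit, caps both of its ends. So compound 3 stands at the limit, with compound 1 the only compound showing a number.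

Compound 4 `CCCCC/C=C\C/C=C\CCCCCCCc1cc(=O)c2c(O)cc(OCOC)cc2o1` differs from compound 3 in the chain only: deca-1,4-dien-1-yl in place of oct-3-en-1-yl on a saturated chain carbon, seven bonds along the chain from an aromatic carbon. No measured step alters this chain, so the shown data give neither size nor direction for it. Among the measured compounds shown here, compound 1 does carry a similar two-double-bond chain, but on a different core, so it sets no step. Compound 4 is therefore expected to remain weak, near the limit of compound 3. The estimated value of compound 4 is 60000 nM, with a range from 15000 nM to 200000 nM. That estimate corresponds to an expected step of an at least 1.1-fold lower number from compound 3 to compound 4 (0.04 log units; that floor lies within the scatter).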

Compound 4, half-maximal inhibitory concentration: > 67200 nM
Compound 4 ended at the assay's limit; the forecaster's own chance of this, stated with the estimate: 60%; at least 1.1-fold (0.04 log units) between middle value and limit.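

No step can be read from compound 3 to compound 4, because both compounds stop at the same limit: the limit of > 67200 nM in this assay, at which 3 of the 4 values shown sit.

The compounds shown leave open whether deca-1,4-dien-1-yl in place of oct-3-en-1-yl changes activity on the shared core at all, and in which direction.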